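From compound 1 to compound 3: replacing 2-oxopropyl

This account rests on a few compounds, and the source may have more. Where it says the series, first, only, none or still open, it means among the compounds named here.

Among the compounds with values here, in a functional assay on SHEP cells (Homo sapiens) for antiproliferative activity, read by spectrophotometry and resazurin assay, with a stated time of 72 h (a higher number here means a weaker inhibitor, a lower number a stronger inhibitor), compound 1 (`CC(=O)CC1Oc2cc(O)ccc2C=C1c1ccc(O)cc1`) gives 124000 nM, the higher of the two numbers so far, and compound 2 (`O=C(CC1Oc2cc(O)ccc2C=C1c1ccc(O)cc1)c1ccc(Br)cc1`) gives 33000 nM. Compound 3 (`Cc1cc(C2Oc3cc(O)ccc3C=C2c2ccc(O)cc2)cc(C)c1N`) carries 4-amino-3,5-dimethylphenyl in place of 2-oxopropyl on a saturated ring carbon, next to the ring oxygen: 4-amino-3,5-dimethylphenyl in place of 2-oxopropyl on a saturated ring carbon. Within the data shown here, only one measured step bears on this change. Putting 4-bromophenyl in place of methyl on a carbonyl carbon gave a 3.8-fold lower number from compound 1 to compound 2 (0.57 log units; beyond the scatter), a modest change beyond the scatter. That step keeps the carbonyl, whereas compound 3 loses it, so the comparison is loose. A lower number of similar size is expected in this assay, and the estimated step is a 3.5-fold lower number from compound 1 to compound 3 (0.55 log units; beyond the scatter). For compound 3 the expected value is 35000 nM, with an estimated range of 9000 nM to 120000 nM.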

Compound 3, half-maximal inhibitory concentration: 102000 nM
The estimate for compound 3 lay 2.9-fold (0.46 log units) below the measured number; measured number inside the range.
By their numbers in this assay, from the lowest: compound 2; then compounds 3 and 1 (each within the scatter of the next).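

In this assay, 4-amino-3,5-dimethylphenyl in place of 2-oxopropyl on the saturated ring carbon gives a 1.2-fold lower number from compound 1 to compound 3 (0.08 log units; within the scatter), so this exchange leaves the number effectively unchanged. An aromatic ring at this position is therefore not enough in itself to produce a drop like a 3.8-fold lower number from compound 1 to compound 2 (0.57 log units; beyond the scatter), which came with the carbonyl retained; compound 3 has lost that carbonyl and carries a different ring substituent. No measurement here offers an explanation for the contrast.

Still open, going by these compounds, is whether the carbonyl, the bromine or both accompany the lower number of compound 2, since compound 3 differs from it in more than one respect. Also open, on these data alone, is how a plain phenyl, a 4-chlorophenyl or a carboxylic acid on the same ring carbon would read in this assay.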